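The compounds below may be only part of what the source reports. "The series", "measured", "known", "first", "only" and "open" are said of these compounds alone.

Compound 1 `Oc1cccc(-c2cc(-c3ccco3)cc(-c3ccccc3O)n2)c1`: in a functional assay on HeLa cells (Homo sapiens) for cytotoxicity, read by CCK-8 assay (on this read-out higher numbers stand for weaker inhibition and lower numbers for stronger inhibition), compound 1 gives > 50000 nM, which is a limit of the assay rather than a number.
Compound 2 `Oc1cccc(-c2cc(-c3ccco3)cc(-c3cccc(O)c3)n2)c1`: in this assay compound 2 gives 5990 nM.
Compound 3 `Oc1ccc(-c2cc(-c3ccco3)cc(-c3cccc(O)c3)n2)cc1`: in this assay compound 3 gives 5170 nM.

Of the two numbers, compound 2 holds the higher one, but its gap to compound 3, a 1.2-fold lower number from compound 2 to compound 3 (0.06 log units; within the scatter), lies within the scatter. The measured steps, an at least 8.3-fold lower number from compound 1 to compound 2 (0.92 log units; beyond the scatter) and an at least 9.6-fold lower number from compound 1 to compound 3 (0.98 log units; beyond the scatter), change only where the hydroxyl sits on one phenyl group. Compound 4 `Oc1cccc(-c2cc(-c3ccccn3)cc(-c3cccc(O)c3)n2)c1` differs from compound 2 elsewhere: pyridin-2-yl in place of furan-2-yl on an aromatic carbon. Among the measured compounds shown here, no measured step touches this position, so the data give no guide in either direction; the expected step is a 1.0-fold higher number from compound 2 to compound 4 (0.00 log units; within the scatter), within the scatter. Compound 4 is therefore estimated at 6000 nM in this assay, with a range from 2000 nM to 20000 nM.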

Compound 4, half-maximal inhibitory concentration: 6500 nM
For compound 4 the middle estimate is 1.1-fold (0.03 log units) below the measured one; low and high end bracket the measured number.
By their numbers in this assay, from the lowest: compounds 3, 2 and 4 (each within the scatter of the next). At a limit, above all of these: compound 1.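

Among the compounds shown here, at this position, opposite the ring nitrogen, the earlier compounds gave no reading, since their steps moved only a hydroxyl on a phenyl group. In this assay, pyridin-2-yl in place of furan-2-yl gives a 1.1-fold higher number from compound 2 to compound 4 (0.04 log units; within the scatter) and so a six-membered aromatic ring stands in for a five-membered one with no change beyond the scatter. No measurement at hand bears on this result.

From the compounds shown here alone, what an amine, a carboxylic acid or a longer chain would do at this position stays open. So does whether a plain phenyl would match pyridin-2-yl.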